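A few compounds are considered here, and "the series" means these few. Any claim that something is new, unique, unknown or untested is made for them only; others in the source may bear on it.

Compound 1 `CC(=O)OCCOn1cnc2c(Cl)nc(I)nc21` gives 9400 nM in a functional assay on MOLT-4 cells (Homo sapiens) for inhibition; on this read-out lower numbers stand for stronger inhibition and higher numbers for weaker inhibition. Compound 2 `CC(O)n1cnc2c(N)nc(I)nc21` reaches only the assay limit, > 500000 nM. Compound 3 `Nc1nc(I)nc2c1ncn2OCCO` likewise reaches only the assay limit, > 500000 nM.

For the measured compounds named here, compound 3 thus stands at the limit of this assay, together with compound 2, while compound 1 is the only compound with a measured number. Compound 4 `COc1nc(I)nc2c1ncn2OCCO` differs from compound 3 in one place: methoxy in place of amino on an aromatic carbon. Going by the values given here, only one measured step is available at all, a step that the two limits leave unreadable from compound 2 to compound 3, and it concerns the group on the aromatic nitrogen rather than the aromatic carbon; it is also unreadable, because both of its ends sit at the limit of > 500000 nM in this assay, at which 2 of the 3 values shown sit. Among the compounds with values here, no measured pair exchanges the group on that aromatic carbon alone; compound 1, with a different group at that carbon and a different chain on the nitrogen, shows a number, and compound 3 shows a limit. The expectation for compound 4 is therefore loosely anchored. Compound 4 is expected to give about 100000 nM. For compound 4 the expected range runs from 10000 nM to 500000 nM, with a fair chance that only a limit is reported. Read against the limit of compound 3, this means an expected step of an at least 5.0-fold lower number from compound 3 to compound 4 (0.69 log units; beyond the scatter).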

Compound 4, half-maximal inhibitory concentration: > 500000 nM
Compound 4 was reported as a limit (the forecaster's own chance of this, stated with the estimate: 45%); middle value at least 5.0-fold (0.69 log units) from the limit.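

Compound 4 gives only a limit, like compound 3, so no step can be read from compound 3 to compound 4 because both ends sit at the same limit: the limit of > 500000 nM in this assay, at which 3 of the 4 values shown sit.

The compounds shown leave open whether methoxy in place of amino on an aromatic carbon changes inhibition at all in this assay, as neither compound 3 nor compound 4 gives a number there.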